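The compounds below may be only part of what the source reports. "The series", "measured", "known", "first", "only" and "open" are said of these compounds alone.

Working notes on the series. Compound 1 `ClCc1ccc(Cn2cnc3nc(Cl)nc(Cl)c32)cc1` and compound 2 `ClCc1ccc(Cn2cnc3c(Cl)nc(Cl)nc32)cc1` carry the same shared core and have both been measured in a functional assay on A498 cells (Homo sapiens) for cytotoxicity, read by sulforhodamine B assay, with a stated time of 48 h; on this read-out lower numbers stand for stronger inhibition of growth and higher numbers for weaker inhibition of growth. In this assay compound 1 gives 11200 nM, and in this assay compound 2 gives 12000 nM. Compound 1 stands at the lower of the two numbers, with compound 2 the nearest and within the scatter of it, so the two values show no difference that can be read as an order. Going by the values given here, no step between measured compounds is available, as compounds 1 and 2 differ in more than one place.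

Compound 3 `ClCc1ccc(Cn2cnc3ncnc(Cl)c32)cc1` is still to be measured in this assay. It differs from compound 1 in a single place: hydrogen in place of chloro on an aromatic carbon. Among the compounds with values here, no measured pair speaks to the loss of a chloro group, so the expectation rests on the change alone. A step of modest size toward weaker inhibition of growth, a somewhat higher number, is expected, though a step within the scatter is about as plausible. For compound 3 the estimate in this assay is 15000 nM, with a range from 5000 nM to 45000 nM. The step this estimate means is expected to be a 1.3-fold higher number from compound 1 to compound 3 (0.13 log units; within the scatter).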

Compound 3, concentration for 50% growth inhibition: 1810 nM
Beside the measured number, compound 3's estimate is 8.3-fold (0.92 log units) above it; the measured number lies below the stated range.
By their numbers in this assay, from the lowest: compound 3; then compounds 1 and 2 (each within the scatter of the next).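

In this assay the step for hydrogen in place of chloro on the aromatic carbon between two ring nitrogen atoms is a 6.2-fold lower number from compound 1 to compound 3 (0.79 log units; beyond the scatter) and points toward stronger inhibition of growth, so a change of one heavy atom at this position registers beyond the scatter, which the earlier pair could not show for lack of any step. The chloro group at this position is therefore not required for the growth inhibition seen with compound 1, and compound 3, which keeps only the chloro group meta to this carbon, inhibits growth more strongly without it. Nothing available gives a reason for the direction or size of this step.

One step cannot tell whether hydrogen is the best replacement at this carbon, or whether an amine, a methoxy group or a methyl group would give a number near that of compound 3 or of compound 1. Equally open, going by these compounds, is what replacing the remaining chloro group of compound 3 would do in this assay, and whether the same step would hold on a different core.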